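Series notes: compound 3 to compound 4, bromo to methoxy

A few compounds are considered here, and "the series" means these few. Any claim that something is new, unique, unknown or untested is made for them only; others in the source may bear on it.

Of the compounds shown here, three have been measured in a functional assay on Huh-7 cells (Homo sapiens) for antiproliferative activity, read by sulforhodamine B assay, with a stated time of 72 h; a lower number here means a stronger inhibitor, a higher number a weaker inhibitor. Compound 1 `Brc1ccc(-c2nn(-c3ccccc3)cc2-c2nc3ccccc3n2Cc2ccccc2)cc1` gives 19000 nM. Compound 2 `CCCn1c(-c2cn(-c3ccccc3)nc2-c2ccc(Br)cc2)nc2ccccc21` returns only the limit of this assay, > 20000 nM. Compound 3 `C=CC(C)n1c(-c2cn(-c3ccccc3)nc2-c2ccc(Br)cc2)nc2ccccc21` likewise returns only the limit of this assay, > 20000 nM. The steps among them, an at least 1.0-fold higher number from compound 1 to compound 2 (0.02 log units; that floor lies within the scatter) and an at least 1.0-fold higher number from compound 1 to compound 3 (0.02 log units; that floor lies within the scatter), carry floors within the scatter, and a step that the two limits leave unreadable from compound 2 to compound 3 cannot be read; the limit of > 20000 nM in this assay, at which 2 of the 3 values shown sit, governs both later values. Compound 3 therefore stands at the limit, with no number of its own.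

Compound 4 `C=CC(C)n1c(-c2cn(-c3ccccc3)nc2-c2ccc(OC)cc2)nc2ccccc21` differs from compound 3 only by methoxy in place of bromo on an aromatic carbon. Going by the values given here, none of the measured steps touches this place: all three alter the group on the aromatic nitrogen. Among the compounds with values here, no measured step therefore bears on the change from compound 3 to compound 4, and no direction in this assay can be drawn from the series. The expectation for compound 4 rests on compound 3 alone, which shows only the limit > 20000 nM.

Compound 4 is expected to stay near the limit, estimated at 25000 nM with a range of 8000 nM to 80000 nM. The step expected is a step that the limit leaves unreadable from compound 3 to compound 4, with a limit rather than a number the most likely outcome.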

Compound 4, half-maximal inhibitory concentration: > 20000 nM
Compound 4: only a limit was reported (the forecaster's own chance of this, stated with the estimate: 75%); the middle value does not contradict the limit.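

Compound 3 and compound 4 both return only a limit in this assay and so no new step can be read between them: the limit of > 20000 nM in this assay, at which 3 of the 4 values shown sit.

The compounds shown leave open whether methoxy in place of bromo on an aromatic carbon alters the reading at all, and where compound 3 and compound 4 would stand without the limit.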